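Chloro in place of fluoro on compound 3

The source may hold more compounds than are shown below. What is called first, only, known or untested is meant among the compounds shown, and "the series" means these compounds.

In a functional assay on MCF7 cells (Homo sapiens) for inhibition, read by MTT assay, with a stated time of 72 h (on this read-out lower numbers stand for stronger inhibition and higher numbers for weaker inhibition), three compounds sharing one core have been measured. Compound 1 `CCc1ccc(NC(=O)C2CCN(C/C=C/c3ccccc3)CC2)cc1` gives 20000 nM, compound 2 `CCCc1ccc(NC(=O)C2CCN(C/C=C/c3ccccc3)CC2)cc1` gives 9030 nM, and compound 3 `O=C(Nc1cccc(F)c1)C1CCN(C/C=C/c2ccccc2)CC1` gives 33000 nM. Two steps fix the place of the last of these: a 1.7-fold higher number from compound 1 to compound 3 (0.22 log units; within the scatter), and a 3.7-fold higher number from compound 2 to compound 3 (0.56 log units; beyond the scatter).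

Compound 4 `O=C(Nc1cccc(Cl)c1)C1CCN(C/C=C/c2ccccc2)CC1` differs from it by chloro in place of fluoro on an aromatic carbon, meta to a large group. Going by the values given here, no measured step exchanges one halogen for another, so none bears on this change directly. Among the compounds with values here, the closest guides are the two steps above, which alter the same ring, and the only step that lengthens a group, a 2.2-fold lower number from compound 1 to compound 2 (0.35 log units; beyond the scatter), which was modest. No step beyond the scatter is therefore expected, with at most a slight drift toward a lower number. The estimated change is a 1.3-fold lower number from compound 3 to compound 4 (0.12 log units; within the scatter). For compound 4 the estimated value is 25000 nM, with an expected range from 11000 nM to 45000 nM.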

Compound 4, half-maximal inhibitory concentration: 16100 nM
Estimate against measurement, compound 4: 1.6-fold (0.19 log units) above, within the range that was stated.
By their numbers in this assay, from the lowest: compounds 2, 4, 1 and 3 (each within the scatter of the next, the first and the last beyond it).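

In this assay, going by these compounds alone, the exchange of fluoro for chloro on an aromatic carbon, meta to a large group, is the first halogen exchange, and it gives a 2.0-fold lower number from compound 3 to compound 4 (0.31 log units; beyond the scatter). The gap that separated compound 3 from compound 2 closes with this change, since a 1.8-fold higher number from compound 2 to compound 4 (0.25 log units; within the scatter) lies within the scatter, as does a 1.2-fold lower number from compound 1 to compound 4 (0.09 log units; within the scatter), so the 3-chlorophenyl amide cannot be told apart from either alkyl-substituted compound. Nothing available explains the size of this halogen step.

From the compounds shown here alone, it remains open whether bromo, methyl or trifluoromethyl on the same aromatic carbon would continue this shift toward lower numbers. Also open, going by these compounds, is how an amine or a carboxylic acid at that place would read out on these cells.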